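The compounds below may be only part of what the source reports. "The series", "measured", "known", "first", "only" and "open" are said of these compounds alone.

Compound 1 `Cc1ccccc1-c1nn(-c2ccc(Cl)cc2)cc1CNCCN1CCN(C)CC1` gives 17000 nM in an ADME assay on Huh-7 cells (Homo sapiens) for cytotoxicity (on this read-out lower numbers stand for higher toxicity in this test and higher numbers for lower toxicity in this test), and compound 2 `Cc1ccccc1-c1nn(-c2ccc(Br)cc2)cc1CNCCN1CCN(C)CC1` gives 9600 nM in this assay; the two differ by a 1.8-fold lower number from compound 1 to compound 2 (0.25 log units; within the scatter). Compound 3 `CCOC(=O)Cn1cc(CNCCN2CCN(C)CC2)c(-c2ccccc2C)n1` carries an (ethoxycarbonyl)methyl group in place of the halophenyl group. In this assay compound 3 reaches only the limit of the measurement, > 20000 nM, so it stands at the least toxic edge of the set with no exact number. Compound 4 `Cc1ccccc1-c1nn(-c2ccc(OC(F)(F)F)cc2)cc1CNCCN1CCN(C)CC1` has not yet been measured; it differs from compound 3 by 4-(trifluoromethoxy)phenyl in place of (ethoxycarbonyl)methyl on an aromatic nitrogen.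

Within the data shown here, the steps that bear on this change run the other way: an at least 1.1-fold higher number from compound 1 to compound 3 (0.07 log units; that floor lies within the scatter) and an at least 2.0-fold higher number from compound 2 to compound 3 (0.31 log units; beyond the scatter). Both show that exchanging a halophenyl group on the aromatic nitrogen for the (ethoxycarbonyl)methyl group raised the number, at least modestly in the case of compound 2. Restoring an aryl group of this kind is therefore expected to move the number back down, toward the values of compound 1 and compound 2, which is the step of an at least 1.8-fold lower number from compound 3 to compound 4 (0.25 log units; that floor lies within the scatter) that this estimate means. Compound 4 is accordingly expected to give about 11000 nM in this assay, somewhere between 5000 nM and 22000 nM.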

Compound 4, half-maximal cytotoxic concentration: 17000 nM
Compound 4: the middle estimate sits 1.5-fold (0.19 log units) below what was measured; measured number inside the range.
By their numbers in this assay, from the lowest: compounds 2, 1 and 4 (each within the scatter of the next). At a limit, above all of these: compound 3.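

With trifluoromethoxy on the phenyl group, this assay gives no change at the digits printed from compound 1 to compound 4 (within the scatter) and a 1.8-fold higher number from compound 2 to compound 4 (0.25 log units; within the scatter), so chloro, bromo and trifluoromethoxy on an aromatic carbon are not told apart by any step among these three compounds. Placing 4-(trifluoromethoxy)phenyl on the aromatic nitrogen in place of (ethoxycarbonyl)methyl gives an at least 1.1-fold lower number from compound 3 to compound 4 (0.07 log units; that floor lies within the scatter), and the true size of this exchange cannot be read because compound 3 stands at a limit of the assay and not at a number: the limit of > 20000 nM in this assay, at which 1 of the 4 values shown sits. Among these compounds, of the steps into compound 3, only an at least 2.0-fold higher number from compound 2 to compound 3 (0.31 log units; beyond the scatter) lies beyond the scatter, and compound 4 adds no second step of that kind.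

The compounds shown leave open whether an amine or a carboxylic acid on the phenyl group, in place of the halogen or trifluoromethoxy, would move the number beyond the scatter. They also leave open whether a plain longer alkyl chain or a free carboxylic acid on the aromatic nitrogen would read like compound 3 or like the aryl compounds.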